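The source may report more compounds than this note shows. Statements on the series, on what has been measured and on what is new or still open speak of the compounds shown alone.

Compound 1 `O=C1O/C(=C\Cn2cc(C3=CCCCC3)nn2)C(OCc2ccccc2)=C1OCc1ccccc1`: in a functional assay on MDA-MB-231 cells (Homo sapiens) for antiproliferative activity, read by MTT assay, with a stated time of 24 h (on this read-out higher numbers stand for weaker inhibition and lower numbers for stronger inhibition), compound 1 gives > 100000 nM, a limit of the assay.
Compound 2 `Cc1ccc(-c2cn(C/C=C3\OC(=O)C(OCc4ccccc4)=C3OCc3ccccc3)nn2)cc1`: compound 2 gives > 100000 nM, again a limit.
Compound 3 `Cc1ccc(-c2cn(CCC3(O)NC(=O)C(OCc4ccccc4)=C3OCc3ccccc3)nn2)cc1`: compound 3 gives 82200 nM.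

Compound 3 thus stands as the only number shown in this assay; the other two values are limits, as summarised at the limit of > 100000 nM in this assay, at which 2 of the 3 values shown sit. Within the data shown here, the single measured step, a step that the two limits leave unreadable from compound 1 to compound 2, cannot be read, so no measured step bears on the change to compound 4 `O=C1NC(O)(CCn2cc(Cc3ccccc3)nn2)C(OCc2ccccc2)=C1OCc1ccccc1`. That change is benzyl in place of 4-methylphenyl on an aromatic carbon. With no readable step to lean on, no shift beyond the usual scatter is expected, and the result may once more come out as a limit rather than a number. Compound 4 is accordingly estimated at 90000 nM, within 30000 nM to 300000 nM, which means an expected step of a 1.1-fold higher number from compound 3 to compound 4 (0.04 log units; within the scatter).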

Compound 4, half-maximal inhibitory concentration: > 100000 nM
Compound 4: no number, only a limit; the forecaster's own chance of this, stated with the estimate: 50%; middle value at least 1.1-fold (0.04 log units) away from the limit.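

In this assay, among these compounds, 4-benzyl-1H-1,2,3-triazol-1-yl in place of 4-(4-methylphenyl)-1H-1,2,3-triazol-1-yl gives an at least 1.2-fold higher number from compound 3 to compound 4 (0.08 log units; that floor lies within the scatter), the first readable step at this position, though only a floor. Compound 4 gives > 100000 nM, which is a limit and not a number. On the core of compound 3, benzyl at this aromatic carbon therefore brings no readable gain, and most of the series sits at the edge of the assay: the limit of > 100000 nM in this assay, at which 3 of the 4 values shown sit.

As far as these compounds go, the true size of this step stays open. So does whether an amine or a carboxylic acid on this aromatic carbon, or a longer chain to the core, would give a number clear of the limit.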